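The source may report more compounds than this note shows. Statements on the series, on what has been measured and on what is new or still open speak of the compounds shown alone.

Values in a functional assay on HeLa cells (Homo sapiens) for inhibition, read by CCK-8 assay, with a stated time of 72 h; a lower number here means a stronger inhibitor, a higher number a weaker inhibitor:
- compound 1 `O=C(/C=C/c1cccnc1)NCCCCc1ccc(S(=O)(=O)Nc2ccccc2)cc1`: 184 nM
- compound 2 `O=C(/C=C/c1cccnc1)NCCCCCc1cccc(S(=O)(=O)Nc2ccccc2)c1`: 105 nM
- compound 3 `Cc1ccccc1NS(=O)(=O)c1cccc(CCCCCCNC(=O)/C=C/c2cccnc2)c1`: 2.34 nM

Compound 3 holds the lowest number of the three, with both other values higher by margins well beyond the scatter. Compound 4 `CC(C)(C)c1ccc(NS(=O)(=O)c2cccc(CCCCCCNC(=O)/C=C/c3cccnc3)c2)cc1` carries 4-(tert-butyl)phenyl in place of 2-methylphenyl on a sulfonamide nitrogen. Within the data shown here, no measured pair isolates a change at this nitrogen, so the expectation rests only on compound 3 at 2.34 nM being the lowest number so far. A modest move toward weaker inhibition is expected, estimated as a 2.6-fold higher number from compound 3 to compound 4 (0.41 log units; beyond the scatter). The estimated value for compound 4 is 6 nM, with an expected range of 1.2 nM to 30 nM.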

Compound 4, half-maximal inhibitory concentration: 1520 nM
Compound 4: middle estimate off by 250-fold (2.40 log units), on the low side, outside the stated range (above it).
By their numbers in this assay, from the lowest: compound 3; then compounds 2 and 1 (each within the scatter of the next); then compound 4.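

In this assay the step of a 650-fold higher number from compound 3 to compound 4 (2.81 log units; beyond the scatter) is large for a change confined to the group on the sulfonamide nitrogen, so this position strongly affects the read-out. Among these compounds, the earlier compounds offered no single change here, and this is the first reading of how far it tolerates substitution. Nothing measured gives a cause for the step.

The 4-(tert-butyl)phenyl and 2-methylphenyl groups differ in both substituent and its place on the phenyl ring, and these two changes cannot be separated. As far as these compounds go, how an amine or a carboxylic acid on that ring would read remains open.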